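Methyl relocation on the allylic ester chain

A few compounds are considered here, and "the series" means these few. Any claim that something is new, unique, unknown or untested is made for them only; others in the source may bear on it.

Compound 2 `CC1=NC(C)=C(C(=O)O)C(c2cccc(Cl)c2)/C1=C(\O)OC/C=C/c1ccc(C)cc1` gives 6.8 nM in a functional assay on thoracic aorta for inhibition of Voltage-gated L-type calcium channel (Rattus norvegicus); on this read-out lower numbers stand for stronger inhibition and higher numbers for weaker inhibition; this is the highest of the two numbers, with compound 1 `CC1=NC(C)=C(C(=O)O)C(c2cccc(Cl)c2)/C1=C(\O)OC/C=C/C1CCCCC1` nearest at 3.7 nM. Compound 3 `CC1=NC(C)=C(C(=O)O)C(c2cccc(Cl)c2)/C1=C(\O)OC/C(C)=C/c1ccccc1` is not yet measured; it carries 1-methyl-2-phenylethenyl in place of 2-(4-methylphenyl)ethenyl on a saturated chain carbon bound to an oxygen on an unsaturated carbon. Among the measured compounds shown here, the only measured step touching this chain end, a 1.8-fold higher number from compound 1 to compound 2 (0.26 log units; within the scatter), stayed within the scatter, so no step beyond the scatter is expected for a 1.0-fold higher number from compound 2 to compound 3 (0.01 log units; within the scatter). Compound 3 is therefore estimated at 7 nM, with a range from 3 nM to 18 nM.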

Compound 3, half-maximal inhibitory concentration: 2.8 nM
Beside the measured number, compound 3's estimate is 2.5-fold (0.40 log units) above it; measured number outside the range, below it.
By their numbers in this assay, from the lowest: compounds 3, 1 and 2 (each within the scatter of the next, the first and the last beyond it).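

Shifting the methyl from the phenyl ring onto the chain, giving 2-methyl-3-phenylprop-2-en-1-yl, is the first change at this chain end to clear the scatter in this assay (a 2.4-fold lower number from compound 2 to compound 3 (0.39 log units; beyond the scatter)), so the arrangement of the same atoms can register here. Against the cyclohexyl chain end the new group stays within the scatter (a 1.3-fold lower number from compound 1 to compound 3 (0.12 log units; within the scatter)). No evidence accounts for this difference.

A plain 3-phenylprop-2-en-1-yl chain end would separate losing the ring methyl from gaining the chain methyl. On these data alone, how an amine on this chain end would read remains open.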